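Changing One Sulfur Stereocentre: What Happens to Cytotoxicity?

The source may hold more compounds than are shown below. What is called first, only, known or untested is meant among the compounds shown, and "the series" means these compounds.

Compound 1 `O=[N+]([O-])c1cn2c(n1)[S@@+]([O-])C[C@@H](OCc1ccc(OC(F)(F)F)cc1)C2` was tested in an ADME assay on MRC5 cells (Homo sapiens) for cytotoxicity; a lower number here means a stronger inhibitor, a higher number a weaker inhibitor. There, compound 1 gives > 64000 nM, which is a limit of the assay and not a number, so no exact figure exists for it. Compound 3 `O=[N+]([O-])c1cn2c(n1)S(=O)(=O)CC(Oc1ccc(OC(F)(F)F)cc1)C2` gives > 64000 nM, which is also a limit. Compound 2 `O=[N+]([O-])c1cn2c(n1)[S+]([O-])CC(Oc1ccc(OC(F)(F)F)cc1)C2` was tested repeatedly and gives 23000 nM; > 64000 nM (2 entries).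

Compound 4 `O=[N+]([O-])c1cn2c(n1)[S@+]([O-])C[C@@H](OCc1ccc(OC(F)(F)F)cc1)C2` has not yet been measured. It differs from compound 1 in one respect: the two compounds have the same atoms and bonds and differ only in configuration as drawn: 1 of 2 stereo elements differ; a stereocentre at a sulfur is drawn S in compound 1 and R in compound 4. Within the data shown here, no measured pair here shows a change of this kind, so there is no direct guide to its size or direction. The expectation rests on compound 1, with its > 64000 nM in this assay. The expected change, a number no higher from compound 1 to compound 4 (the limit leaves the size open), is no step beyond the scatter in either direction. Compound 4 is estimated at 64000 nM, with an expected range from 25000 nM to 100000 nM.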

Compound 4, half-maximal inhibitory concentration: 50000 nM
Estimate against measurement, compound 4: 1.3-fold (0.11 log units) above, and the stated range covers the measured number.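

Among these compounds, for the first time, a pair of measured compounds isolates the sulfur stereocentre in this assay, and changing it from S to R gives an at least 1.2-fold lower number from compound 1 to compound 4 (0.10 log units; that floor lies within the scatter). Going by these compounds, the figure for compound 1, > 64000 nM, is a limit of the assay and not a number, so the true size of this step remains unknown. Any difference between the two compounds can rest on only one feature: the fact that compounds 1 and 4 differ only in the configuration as drawn.

The compounds shown leave open whether reversing the carbon stereocentre would give a similar result with either sulfur configuration. They also leave open how an amine or a carboxylic acid in place of the trifluoromethoxy group would fare in this assay.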